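Swapping Chloro for Bromo: Expected Cytotoxicity of Compound 4

The source may hold more compounds than are shown below. What is called first, only, known or untested is meant among the compounds shown, and "the series" means these compounds.

Compound 1 `COc1cc(/C=C2\CN(C)C/C(=C\c3ccc(Cl)cc3)C2=O)cc(OC)c1OC` and compound 2 `COc1cc(/C=C2\CN(C)C/C(=C\c3ccc(Br)cc3)C2=O)cc(OC)c1OC` share one core and differ only in a single spot: bromo in place of chloro on an aromatic carbon. In a functional assay on HeLa cells (Homo sapiens) for cytotoxicity, read by MTT assay, with a stated time of 24 h (a higher number here means a weaker inhibitor, a lower number a stronger inhibitor), compound 1 gives only a limit of the assay, not a number, namely > 20000 nM. In this assay compound 2 gives 11900 nM. The step between them is an at least 1.6-fold lower number from compound 1 to compound 2 (0.22 log units; that floor lies within the scatter), and its floor comes from the limit of > 20000 nM in this assay, at which 2 of the 3 values shown sit.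

Compound 3 `CN1C/C(=C\c2ccc(Cl)cc2)C(=O)/C(=C/c2cccc([N+](=O)[O-])c2)C1` is built on a different core; the difference between the two cores is not broken down here. In this assay compound 3 also gives only a limit, > 20000 nM. Compound 4 `CN1C/C(=C\c2ccc(Br)cc2)C(=O)/C(=C/c2cccc([N+](=O)[O-])c2)C1` has not been measured. It differs from compound 3 in exactly the same way, (bromo in place of chloro on an aromatic carbon), at the same place as before.

Going by the values given here, the one measured step of this change is a small shift that may merely be scatter, and the starting value for compound 3 is itself a limit. On that basis, the expected step is an at least 1.2-fold lower number from compound 3 to compound 4 (0.09 log units; that floor lies within the scatter). Compound 4 is estimated at 16000 nM, expected to fall between 8000 nM and 40000 nM.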

Compound 4, half-maximal inhibitory concentration: 11900 nM
Compound 4: the middle estimate sits 1.3-fold (0.13 log units) above what was measured; the range from low to high includes it.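

In this assay, the swap from 4-chlorophenyl to 4-bromophenyl gives an at least 1.6-fold lower number from compound 3 to compound 4 (0.22 log units; that floor lies within the scatter). Set beside the same swap on the other core, the two steps point the same way, and no compound shown goes against that, but their sizes cannot be compared: the same change on two cores in this assay, an at least 1.6-fold lower number (0.22 log units; that floor lies within the scatter) from compound 1 to compound 2 and an at least 1.6-fold lower number (0.22 log units; that floor lies within the scatter) from compound 3 to compound 4; the limit leaves it open whether they differ This shows only that the bromo compound on each core gives a measured number while its chloro partner gives a limit; it does not show how large either step truly is, or that the change carries over from one core to another with a real effect, and what holds both steps back is this: the limit of > 20000 nM in this assay, at which 2 of the 4 values shown sit.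

The compounds shown leave open how a chloro partner with a measured number would compare with its bromo partner, which would turn each floor into a full step. They also leave open what other groups at this place on the ring would do, such as a fluoro, an amine or a carboxylic acid.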